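Replacing the Substituted Phenyl Group of Compound 3

This account rests on a few compounds, and the source may have more. Where it says the series, first, only, none or still open, it means among the compounds named here.

In an ADME assay on microsomes from liver (Rattus norvegicus) for metabolic stability, read by LC-MS, using NADPH, at 37 degrees C (on this read-out lower numbers stand for a shorter-lived compound and higher numbers for a longer-lived compound), compound 3 (`COc1cccc(Cl)c1-c1nc(CN2CCC(C(=O)NCCCN3C[C@H](C)C[C@H](C)C3)CC2)c(C)o1`) gives 0.055 h and compound 1 (`Cc1oc(-c2c(Cl)cccc2C(F)(F)F)nc1CN1CCC(C(=O)NCCCN2C[C@H](C)C[C@H](C)C2)CC1`) gives 0.03 h, values within the scatter of each other. Compound 2 (`Cc1ccc(-c2nc(CN3CCC(C(=O)NCCCN4C[C@H](C)C[C@H](C)C4)CC3)c(C)o2)cc1`) reads > 0.5 h, which is a limit of the assay. Compound 4 (`Cc1ccc(-c2nc(CN3CCC(C(=O)NCCCN4C[C@H](C)C[C@H](C)C4)CC3)c(C)o2)c(C)c1`) carries 2,4-dimethylphenyl in place of 2-chloro-6-methoxyphenyl on an aromatic carbon. Its group resembles the 4-methylphenyl of compound 2 more than the groups of compound 1 and compound 3. The relevant measured changes are an at least 16-fold higher number from compound 1 to compound 2 (1.22 log units; beyond the scatter) and an at least 9.0-fold lower number from compound 2 to compound 3 (0.95 log units; beyond the scatter), both beyond the scatter. A sizeable rise is therefore expected, with an estimated 5.5-fold higher number from compound 3 to compound 4 (0.74 log units; beyond the scatter). For compound 4, the expected half-life is 0.3 h, with an estimated range of 0.1 h to 0.8 h.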

Compound 4, half-life: > 0.5 h
Compound 4 was reported as a limit; the forecaster's own chance of this, stated with the estimate: 40%; middle value at least 1.6-fold (0.22 log units) from the limit.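

In this assay, 2,4-dimethylphenyl on this aromatic carbon gives an at least 9.0-fold higher number from compound 3 to compound 4 (0.95 log units; beyond the scatter), and against the other group it gives an at least 16-fold higher number from compound 1 to compound 4 (1.22 log units; beyond the scatter). Compound 2 had shown such a rise only for 4-methylphenyl, whereas compound 4 shows that a phenyl group with a second methyl also reaches the limit. The step from compound 2 to compound 4 cannot be read, as both are limits: the limit of > 0.5 h in this assay, at which 2 of the 4 values shown sit.

The compounds shown leave open how long-lived compound 2 and compound 4 really are. They also leave open whether 2-chloro-4-methylphenyl would stay at this limit.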